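The source may hold more compounds than are shown below. What is called first, only, known or untested is meant among the compounds shown, and "the series" means these compounds.

Compound 1, with the structure `Fc1ccccc1Cn1nc(-c2ncccn2)c2cccnc21`, and compound 2, with the structure `CCCCc1cnc(-c2nn(Cc3ccccc3F)c3ncccc23)nc1N`, were both tested in a functional assay (aorta) with Oryctolagus cuniculus as the target; on this read-out lower numbers stand for stronger inhibition and higher numbers for weaker inhibition. In this assay compound 1 gives 1250 nM, and compound 2 gives 218000 nM. Among the compounds with values here, of the two numbers known, compound 2 has the highest one; its only neighbour is compound 1, whose number is far lower, well beyond the usual scatter of repeated measurements. Compound 2 is thus the weaker inhibitor of this pair by a wide margin.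

Compound 3, with the structure `CS(=O)(=O)c1cnc(-c2nn(Cc3ccccc3F)c3ncccc23)nc1N`, has not yet been measured. It differs from compound 2 in a single place: methylsulfonyl in place of butyl on an aromatic carbon. Within the data shown here, no measured pair shows the effect of such a change, so the size of the step cannot be read from the numbers known so far. The step from compound 2 to compound 3 in this assay is expected to be a 2.2-fold lower number from compound 2 to compound 3 (0.34 log units; beyond the scatter), toward a somewhat lower number. For compound 3 the expected value in this assay is 100000 nM, with a likely range from 20000 nM to 500000 nM.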

Compound 3, half-maximal inhibitory concentration: 261000 nM
Compound 3: middle estimate off by 2.6-fold (0.42 log units), on the low side; the range from low to high includes it.
By their numbers in this assay, from the lowest: compound 1; then compounds 2 and 3 (each within the scatter of the next).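

In this assay, replacing butyl with methylsulfonyl on this aromatic carbon, ortho to an amino group, gives a 1.2-fold higher number from compound 2 to compound 3 (0.08 log units; within the scatter) and so leaves the two compounds indistinguishable. Within the data shown here, this is the first direct look at this position, and the two groups are very different in makeup even though they are the same size by heavy-atom count: butyl is a plain carbon chain with no hydrogen-bond acceptors, whereas methylsulfonyl brings in sulfur, oxygen and hydrogen-bond acceptors, yet this pair shows no measurable response to the exchange. No independent measurement is available that would explain this absence of a difference.

One pair cannot show whether other groups at this carbon would also leave the read-out unchanged, such as a bare hydrogen, a methyl, a longer chain, a carboxylic acid or a basic amine. Going by these compounds, the role of the neighbouring amino group also remains open, since it is present in both compounds and a version with a hydrogen in its place would be needed to isolate its contribution.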